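This account rests on a few compounds, and the source may have more. Where it says the series, first, only, none or still open, it means among the compounds named here.

Measured in a functional assay on MCF7 cells (Breast, Homo sapiens) for inhibition; a higher number here means a weaker inhibitor of growth, a lower number a stronger inhibitor of growth:
Compound 1 `Nc1ccc(-c2nc3cc(F)ccc3s2)cc1`: < 10 nM (a limit)
Compound 2 `Nc1ccc(-c2nc3cc(F)ccc3s2)cc1Cl`: < 10 nM (a limit)
Compound 3 `Cc1cc(-c2nc3ccc(F)cc3s2)ccc1N`: < 10 nM (a limit)

In this assay compound 2 gives < 10 nM, which is a limit and not a number. The whole set looks the same, with the limit of < 10 nM in this assay, at which 3 of the 3 values shown sit, so compound 2 cannot be ranked against compound 1 or compound 3.

Compound 4 `Nc1ccc(-c2nc3cc(F)ccc3s2)cc1I` differs from compound 2 by a single exchange, iodo in place of chloro on an aromatic carbon, ortho to an amino group and meta to a large group: iodo in place of chloro on an aromatic carbon. For the measured compounds named here, the only measured step that bears on it is a step that the two limits leave unreadable from compound 1 to compound 2, chloro in place of hydrogen on an aromatic carbon. Going by the values given here, that step gives no size to carry over, and no measured compound carries iodo. The expectation is therefore modest: no change beyond the usual scatter, with neither direction favoured, and quite possibly another limit as the reported result. The expected step is a step that the limit leaves unreadable from compound 2 to compound 4. For compound 4 the estimated value is 5 nM, with an expected range from 1 nM to 15 nM.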

Compound 4, concentration for 50% growth inhibition: < 10 nM
Compound 4 was reported as a limit; the forecaster's own chance of this, stated with the estimate: 75%; the middle value does not contradict the limit.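

In this assay compound 4 gives < 10 nM, which is a limit and not a number. For the compounds shown here, no step among compound 1, compound 2 and compound 4 can be read, because all three share one limit: the limit of < 10 nM in this assay, at which 4 of the 4 values shown sit. The compounds shown leave open whether hydrogen, chloro or iodo on this aromatic carbon changes growth inhibition at all.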